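A smaller aromatic group enters at compound 3

A few compounds are considered here, and "the series" means these few. Any claim that something is new, unique, unknown or untested is made for them only; others in the source may bear on it.

Measured in a physicochemical assay for solubility, with a stated time of 24 h, at pH 6.8; on this read-out higher numbers stand for higher solubility and lower numbers for lower solubility:
- compound 1 `O=C(NC[C@@H]1[C@H]2CN(C(=O)/C=C/c3cc(Cl)cc(Cl)c3)C[C@@H]12)c1ccc2[nH]c(=O)oc2c1`: < 1 ug/mL
- compound 2 `O=C(NC[C@@H]1[C@H]2CN(C(=O)C3CC3c3cc(Cl)cc(Cl)c3)C[C@@H]12)c1ccc2[nH]c(=O)oc2c1`: < 1 ug/mL
- compound 3 `CC(OC(=O)N1C[C@@H]2[C@@H](CNC(=O)c3ccc4[nH]c(=O)oc4c3)[C@@H]2C1)c1cc(Cl)cc(Cl)c1`: < 1 ug/mL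

Compound 3 gives < 1 ug/mL in this assay, which is a limit of the assay and not a number. The other two measured compounds stand at the same place: the limit of < 1 ug/mL in this assay, at which 3 of the 3 values shown sit.

Compound 4 `Cc1cc(COC(=O)N2C[C@@H]3[C@@H](CNC(=O)c4ccc5[nH]c(=O)oc5c4)[C@@H]3C2)no1` differs from compound 3 in one group: a group of 7 heavy atoms (5 carbon, 1 nitrogen, 1 oxygen; one five-membered aromatic ring with 2 hetero atoms) in place of a group of 10 heavy atoms (8 carbon, 2 chlorine; one six-membered aromatic ring of carbon only), on an oxygen next to a carbonyl group. The entering (5-methyl-1,2-oxazol-3-yl)methyl sits on an oxygen next to a carbonyl group.

Two measured steps reach compound 3, a step that the two limits leave unreadable from compound 1 to compound 3 and a step that the two limits leave unreadable from compound 2 to compound 3. Neither has a readable size, and neither involves the group now entering, so the data give no direct guide to this change. The expectation therefore rests on the structural change and on compound 3, with its limit of < 1 ug/mL, and it carries wide uncertainty. An upward move is expected, estimated as an at least 12-fold higher number from compound 3 to compound 4 (1.07 log units; beyond the scatter). Compound 4 is expected at about 12 ug/mL, with an estimated range of 2 ug/mL to 80 ug/mL.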

Compound 4, solubility: 63 ug/mL
The estimate for compound 4 lay 5.3-fold (0.72 log units) below the measured number; measured number inside the range.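

In this assay, the steps among compound 1, compound 2 and compound 3 cannot be read, and this place first shows a readable change when (5-methyl-1,2-oxazol-3-yl)methyl enters on an oxygen next to a carbonyl group, with an at least 63-fold higher number from compound 3 to compound 4 (1.79 log units; beyond the scatter). The comparisons with the other two compounds are of the same printed size, with an at least 63-fold higher number from compound 2 to compound 4 (1.79 log units; beyond the scatter) and an at least 63-fold higher number from compound 1 to compound 4 (1.79 log units; beyond the scatter), and each gives only a lower bound on the step. Compound 4 is the only compound shown that stands off the limit: the limit of < 1 ug/mL in this assay, at which 3 of the 4 values shown sit.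

The step replaces the chlorine-bearing aromatic ring of carbon only with a five-membered aromatic ring with hetero atoms in one move, and the compounds shown do not separate the loss of chlorine from the change of ring. From the compounds shown here alone, whether a phenyl group without chlorine or an amine in this place would also leave the limit stays open.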